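Fluorophenyl variation on the shared core: compound 3

The source may hold more compounds than are shown below. What is called first, only, known or untested is meant among the compounds shown, and "the series" means these compounds.

Compound 1 `Fc1ccccc1Nc1nc2nonc2nc1NC1CCCCC1` carries cyclohexyl on the nitrogen and, in an assay on mitochondria from L6 cells (Rattus norvegicus) for activation, with a stated time of 90 min (a higher number here means that more compound is needed for the effect, a lower number that less compound is needed), compound 1 gives 13400 nM. Within the data shown here, compound 2 `Fc1cccc(Nc2nc3nonc3nc2Nc2ccccc2F)c1` gives 190 nM in this assay, the lowest of the two numbers so far; the only neighbour is compound 1, and the change between them reads a 71-fold lower number from compound 1 to compound 2 (1.85 log units; beyond the scatter). Compound 3 `Fc1ccc(Nc2nc3nonc3nc2Nc2ccccc2F)cc1` is the next member; its difference from compound 2 is 4-fluorophenyl in place of 3-fluorophenyl on a nitrogen on an aromatic ring. Among the measured compounds shown here, no measured step covers a move between two fluorophenyl groups: the single step seen swaps cyclohexyl for 3-fluorophenyl and says nothing about where the fluorine sits on the ring. The expectation for compound 3 is therefore a step of a 1.3-fold higher number from compound 2 to compound 3 (0.12 log units; within the scatter), that is no change beyond the scatter, with wide uncertainty. Compound 3 is estimated at 250 nM in this assay, expected between 60 nM and 1200 nM.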

Compound 3, half-maximal effective concentration: 2300 nM
For compound 3 the middle estimate is 9.2-fold (0.96 log units) below the measured one; the measured number lies above the stated range.
By their numbers in this assay, from the lowest: compound 2; then compound 3; then compound 1.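

The fluorine's place on this aryl group matters in this assay: the two groups have the same atoms, yet the change gives (a 12-fold higher number from compound 2 to compound 3 (1.08 log units; beyond the scatter)), so 3-fluorophenyl and 4-fluorophenyl cannot be treated as equivalent on this nitrogen. The gain over cyclohexyl also depends on which fluorophenyl group is present, with (a 5.8-fold lower number from compound 1 to compound 3 (0.77 log units; beyond the scatter)) set against (a 71-fold lower number from compound 1 to compound 2 (1.85 log units; beyond the scatter)), so the earlier step cannot stand for aryl replacement in general. No supporting measurement bears on why the fluorine's place has this effect.

Open, from the compounds shown here alone, is how plain phenyl or a pyridyl group would read at this nitrogen. Also open, going by these compounds, is whether a chlorine, methoxy group or nitrile on the ring would follow the same order as fluorine.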